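Urea versus amide on the shared core: growth inhibition notes

The source may hold more compounds than are shown below. What is called first, only, known or untested is meant among the compounds shown, and "the series" means these compounds.

Measured so far:
compound 1 `CNC(=O)c1cc(Oc2ccc3nc(NC(=O)c4ccc(Cl)cc4)sc3c2)ccn1` — 80.5%
compound 2 `CNC(=O)c1cc(Oc2ccc3nc(NC(=O)Nc4ccc(C5CCN(C(C)C)CC5)cc4)sc3c2)ccn1` — 95.5%

In a functional assay on HCT-116 cells (Homo sapiens) for inhibition, read by MTT assay, with a stated time of 2 days, tested at 100 uM (a lower number here means less inhibition of growth, a higher number more inhibition of growth at the concentration tested), compound 2 gives 95.5% and stands at the top of the two numbers; its nearest neighbour is compound 1, which gives 80.5%, a gap beyond the scatter. Within the data shown here, no step between measured compounds differing in one place is available, so the two values can only be set side by side.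

Compound 3 `CNC(=O)c1cc(Oc2ccc3nc(NC(=O)Nc4ccc(Br)cc4)sc3c2)ccn1` is not yet measured in this assay. Relative to compound 2 the change is bromo in place of 1-isopropylpiperidin-4-yl on an aromatic carbon. Compound 1 carries a halogen on the same ring, though on an amide rather than a urea, and gives 80.5%. A moderate drop from compound 2, a number 11.5 percentage points lower from compound 2 to compound 3 (beyond the scatter), is therefore expected, likely beyond the scatter but not certainly so. For compound 3 the estimated result is 84%, with a range from 68% to 96%.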

Compound 3, percent growth inhibition at one concentration: 80%
For compound 3 the middle estimate is 4 percentage points above the measured one; the measured number falls inside the stated range.
By their numbers in this assay, from the lowest: compounds 3 and 1 (each within the scatter of the next); then compound 2.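

In this assay, among these compounds, bromo in place of 1-isopropylpiperidin-4-yl on an aromatic carbon gives a number 15.5 percentage points lower from compound 2 to compound 3 (beyond the scatter), the first reading of this position with the urea held constant, and it shows that the group here can shift growth inhibition beyond the scatter. The other step, (4-bromophenyl)amino in place of 4-chlorophenyl on a carbonyl carbon, gives a number 0.5 percentage points lower from compound 1 to compound 3 (within the scatter), so the urea with bromo and the amide with chloro cannot be told apart in this assay, and the urea alone does not carry the higher value of compound 2. Nothing measured accounts for either step.

Still open, as far as these compounds go, is whether the ring, its nitrogen or the isopropyl matters: a cyclohexyl or an unsubstituted piperidin-4-yl at this place would separate these. A dimethylamino group would test whether any ring is needed.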